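Side-chain acetyl to hydrogen: compound 2 to compound 3

This account rests on a few compounds, and the source may have more. Where it says the series, first, only, none or still open, it means among the compounds named here.

Compound 1 `CC(=O)OCCOn1cnc2c(Cl)nc(N)nc21`; compound 2 `CC(=O)OC(C)n1cnc2c(Cl)nc(I)nc21`.

In a functional assay on HEp-2 cells (Homo sapiens) for inhibition (a lower number here means a stronger inhibitor, a higher number a weaker inhibitor), compound 1 gives only a limit, > 500000 nM, which is the limit of > 500000 nM in this assay, at which 1 of the 2 values shown sits. In this assay, among the compounds with values here, compound 2 gives 6310 nM, the only true number among the two values shown, so it is the sole anchor for this series. Compound 3 `CC(O)n1cnc2c(Cl)nc(I)nc21` differs from compound 2 by hydrogen in place of acetyl on an oxygen on a saturated carbon. Within the data shown here, no measured step of this kind is available. A weakening step in this assay is expected, of a 2.4-fold higher number from compound 2 to compound 3 (0.38 log units; beyond the scatter), somewhat beyond the scatter, though with wide uncertainty. For compound 3 the estimate is 15000 nM, with a range from 3000 nM to 80000 nM.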

Compound 3, half-maximal inhibitory concentration: > 500000 nM
Compound 3: only a limit was reported; the forecaster's own chance of this, stated with the estimate: 20%; at least 33-fold (1.52 log units) between middle value and limit.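

In this assay, within the data shown here, the change from acetoxy to hydroxy gives an at least 79-fold higher number from compound 2 to compound 3 (1.89 log units; beyond the scatter), the first readable step and a large one. The acetyl on this oxygen therefore matters here: compound 2 keeps a true value, whereas compound 3 gives only a limit. That makes the step a minimum, not a measured size: the limit of > 500000 nM in this assay, at which 2 of the 3 values shown sit.

From the compounds shown here alone, whether the acetyl itself is required, or any group on this oxygen would serve, remains open. A methyl ether, a propanoyl ester or a carbamate at this oxygen would separate those readings.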